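Tellurium series: the step from compound 1 to compound 4

This account rests on a few compounds, and the source may have more. Where it says the series, first, only, none or still open, it means among the compounds named here.

In a functional assay on HCT-116 cells (Homo sapiens) for cytotoxicity, read by MTT assay, with a stated time of 24 h (on this read-out higher numbers stand for weaker inhibition and lower numbers for stronger inhibition), compound 1 `O=S(=O)(O)OCCCCCCCCCC[Te]c1ccccc1` gives 7470 nM. Compound 2 `O=S(=O)(O)OCCCCCCCC[Te]c1ccccc1` gives 5990 nM, which lies within the scatter of compound 1, so these two numbers cannot be ordered. Compound 3 `O=S(=O)(O)OCCCCCCCC[Se]c1ccccc1` gives > 100000 nM, and this is a limit of the assay, not a number.

Compound 4 `O=S(=O)(O)OCCCCCCCCCCC[Te]c1ccccc1` is not yet measured. It departs from compound 1 by (sulfooxy)methyl in place of sulfooxy on a saturated chain carbon, ten or more bonds along the chain from a tellurium atom.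

Within the data shown here, one measured step bears on this change, a change at the same chain end: a 1.2-fold lower number from compound 1 to compound 2 (0.10 log units; within the scatter). That step is small and gives no direction, so no shift beyond the scatter is expected in this assay. The expected step is a 1.0-fold higher number from compound 1 to compound 4 (0.00 log units; within the scatter), with no direction favoured. Compound 4 is estimated at 7500 nM, with an expected range of 3500 nM to 16000 nM.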

Compound 4, half-maximal inhibitory concentration: 9730 nM
The estimate for compound 4 lay 1.3-fold (0.11 log units) below the measured number, and the stated range covers the measured number.
By their numbers in this assay, from the lowest: compounds 2, 1 and 4 (each within the scatter of the next). At a limit, above all of these: compound 3.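

In this assay, the change at this chain end gives a 1.3-fold higher number from compound 1 to compound 4 (0.11 log units; within the scatter), so (sulfooxy)methyl in place of sulfooxy leaves the read-out unresolved from that of compound 1. The earlier step, a 1.2-fold lower number from compound 1 to compound 2 (0.10 log units; within the scatter), covered only the other change at this chain end; with both steps read, compound 1 has two neighbours of differing chain end, and neither can be separated from it. No measured property among the data given bears on this result.

As far as these compounds go, a longer chain than that of compound 4 remains open, so the limit of this flat stretch of the series is not defined. Also open, from the compounds shown here alone, is whether a carboxylic acid or an amine in place of sulfooxy at the chain end would keep the number within the scatter of compound 1.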